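The compounds below may be only part of what the source reports. "The series", "measured", "known", "first", "only" and "open" are said of these compounds alone.

Measured in a functional assay on MCF7 cells (Homo sapiens) for inhibition, read by MTT assay, with a stated time of 24 h; a lower number here means a stronger inhibitor of growth, a higher number a weaker inhibitor of growth:

- Compound 1 `COc1cccc(C(=O)n2c(-c3cn(C)c4ccc(OC)cc34)nc3ccccc32)c1`: 14600 nM
- Compound 2 `COc1ccccc1C(=O)n1c(-c2cn(C)c3ccc(Br)cc23)nc2ccccc21`: 36200 nM
- Compound 3 `COc1cccc(C(=O)n2c(-c3cn(C)c4ccc(Br)cc34)nc3ccccc32)c1`: 18200 nM

Compound 3, at 18200 nM, does not separate from either of the other two compounds. It lies within the scatter of both: a 1.2-fold higher number from compound 1 to compound 3 (0.10 log units; within the scatter) and a 2.0-fold lower number from compound 2 to compound 3 (0.30 log units; within the scatter).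

In compound 4 `Cn1cc(-c2nc3ccccc3n2C(=O)c2cccc(Br)c2)c2cc(Br)ccc21` the 3-methoxyphenyl of compound 3 becomes 3-bromophenyl, with bromo in place of methoxy on an aromatic carbon, meta to a large group (bromo in place of methoxy on an aromatic carbon).

Among the compounds with values here, the closest precedent is the same swap made on the shared core instead of on this ring, which gave a 1.2-fold higher number from compound 1 to compound 3 (0.10 log units; within the scatter). The move of the methoxy group on this ring, seen in compound 2 and compound 3, also stayed within the scatter. Within the data shown here, no measured compound carries bromo on this ring, so the precedent is only indirect. On this evidence, no change beyond the scatter is expected in this assay, in either direction. The estimate means a 1.0-fold lower number from compound 3 to compound 4 (0.00 log units; within the scatter). Compound 4 is estimated at 18000 nM, with an expected range from 8000 nM to 40000 nM.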

Compound 4, concentration for 50% growth inhibition: 68200 nM
Estimate against measurement, compound 4: 3.8-fold (0.58 log units) below, outside the stated range (above it).
By their numbers in this assay, from the lowest: compounds 1, 3, 2 and 4 (each within the scatter of the next, the first and the last beyond it).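

In this assay, bromo in place of methoxy on this ring gave a 3.7-fold higher number from compound 3 to compound 4 (0.57 log units; beyond the scatter), whereas the same swap on the shared core gave a 1.2-fold higher number from compound 1 to compound 3 (0.10 log units; within the scatter), so the outcome of this swap depends on where it is made. The 3-bromophenyl group does not separate compound 4 from the 2-methoxyphenyl compound, with a 1.9-fold higher number from compound 2 to compound 4 (0.28 log units; within the scatter), so among these compounds only the 3-methoxyphenyl group of compound 3 stands apart from compound 4. Nothing available explains why this ring responds to the swap when the core does not. Still open, on these data alone, is whether the methoxy group itself matters here or whether another group in its place, such as an amine or a hydroxyl, would hold the number near that of compound 3.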